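A few compounds are considered here, and "the series" means these few. Any claim that something is new, unique, unknown or untested is made for them only; others in the source may bear on it.

Three compounds share one core and differ only in the group carried on one aromatic carbon. Compound 1 `N#Cc1cnc(NCc2cncnc2C(F)(F)F)cc1N[C@H]1CC[C@@H](O)CC1` gives 450 nM in an assay on isolated protein for inhibition of protein kinase C delta type (Homo sapiens), read by TR-FRET, with a stated time of 2 h; on this read-out lower numbers stand for stronger inhibition and higher numbers for weaker inhibition. Compound 2 `CC(C)(F)c1ncncc1CNc1cc(N[C@H]2CC[C@@H](O)CC2)c(C#N)cn1` gives 32 nM. Compound 3 `N#Cc1cnc(NCc2cncnc2-c2ccccc2)cc1N[C@H]1CC[C@@H](O)CC1` gives 90 nM, the second highest of the three numbers. The steps measured so far are a 5.0-fold lower number from compound 1 to compound 3 (0.70 log units; beyond the scatter) and a 2.8-fold higher number from compound 2 to compound 3 (0.45 log units; beyond the scatter). Compound 4 `COc1ncncc1CNc1cc(N[C@H]2CC[C@@H](O)CC2)c(C#N)cn1` changes the same spot: methoxy in place of phenyl on an aromatic carbon. Among the measured compounds shown here, no measured step involves methoxy, so the expectation leans on compound 1, which with trifluoromethyl in that place gives 450 nM. A step toward weaker inhibition is therefore expected, a 3.3-fold higher number from compound 3 to compound 4 (0.52 log units; beyond the scatter). For compound 4 the estimate is 300 nM, with a range from 80 nM to 1100 nM.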

Compound 4, half-maximal inhibitory concentration: 800 nM
Compound 4: middle estimate off by 2.7-fold (0.43 log units), on the low side; measured number inside the range.
By their numbers in this assay, from the lowest: compound 2; then compound 3; then compounds 1 and 4 (each within the scatter of the next).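

Replacing phenyl with methoxy gives an 8.9-fold higher number from compound 3 to compound 4 (0.95 log units; beyond the scatter), and replacing 1-fluoro-1-methylethyl with methoxy gives a 25-fold higher number from compound 2 to compound 4 (1.40 log units; beyond the scatter), so this position does not accept every group equally. Methoxy and trifluoromethyl cannot be told apart, with a 1.8-fold higher number from compound 1 to compound 4 (0.25 log units; within the scatter), and both leave inhibition weaker than phenyl or 1-fluoro-1-methylethyl does. Nothing available explains these differences.

Still open, on these data alone, is where an amine, an ethyl group or a cyclopropyl group would fall in this place, and whether this order of groups would hold on another core.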